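The compounds below may be only part of what the source reports. "The series", "measured", "known", "first", "only" and "open" are said of these compounds alone.

Working notes on the series. Two compounds have been run in a functional assay on NCI-H1975 cells (Homo sapiens) for antiproliferative activity, read by MTT assay, with a stated time of 72 h; on this read-out higher numbers stand for weaker inhibition and lower numbers for stronger inhibition. Compound 1, `COc1cc(N(C)CCN(C)C)c(NC(=O)/C=C\C(C)C)cc1Nc1ncc(C#N)c(-c2cn(C)c3ccccc23)n1`, gives 1110 nM. Among the measured compounds shown here, compound 2, `CC/C=C\C(=O)Nc1cc(Nc2ncc(C#N)c(-c3cn(C)c4ccc(F)cc34)n2)c(OC)cc1N(C)CCN(C)C`, gives 10200 nM, the higher of the two numbers, and the gap between the two lies beyond the scatter; as compound 1 and compound 2 differ in more than one place, the two values alone show only that compound 2 sits at the weaker end of what has been measured.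

Compound 3, `COc1cc(N(C)CCN(C)C)c(NC(=O)/C=C\C(C)C)cc1Nc1ncc(C#N)c(-c2cn(C)c3ccc(F)cc23)n1`, has not yet been run. It differs from compound 2 by methyl in place of hydrogen on a saturated chain carbon bound to a double-bonded chain carbon and a saturated chain carbon, and it shares with compound 1 the 3-methylbut-1-en-1-yl chain on the amide. For the measured compounds named here, no single-change step is available to size this move, so the expectation rests on the only comparison in hand. Compound 3 is expected to give a lower number than compound 2, and the step of a 4.1-fold lower number from compound 2 to compound 3 (0.61 log units; beyond the scatter) is the estimated size of that move, judged moderate rather than large. For compound 3 the expected value is 2500 nM, within a range of 700 nM to 9000 nM, leaning toward compound 1 because compound 1 gives 1110 nM with the same chain.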

Compound 3, half-maximal inhibitory concentration: 1130 nM
The estimate for compound 3 lay 2.2-fold (0.34 log units) above the measured number; the measured number falls inside the stated range.
By their numbers in this assay, from the lowest: compounds 1 and 3 (each within the scatter of the next); then compound 2.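

In this assay the change from ethyl to isopropyl at the end of the amide chain, read also as but-1-en-1-yl to 3-methylbut-1-en-1-yl, gives a 9.0-fold lower number from compound 2 to compound 3 (0.96 log units; beyond the scatter) as a single-place step, so one methyl on this saturated chain carbon is enough to produce a gap beyond the scatter, which the comparison of compound 1 with compound 2 could not isolate. On the chain of 3-methylbut-1-en-1-yl, fluoro in place of hydrogen on an aromatic carbon gives a 1.0-fold higher number from compound 1 to compound 3 (0.01 log units; within the scatter) and so separates the two compounds by no more than the scatter, which places the difference seen at the start of the series on the chain rather than on the fluoro. Nothing in hand bears on the reason for either result.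

Going by these compounds, whether the chain step carries over to the core without fluoro stays open, as does the size of the effect of fluoro on the but-1-en-1-yl chain. On these data alone, how a longer chain, a cyclopropyl group or a tert-butyl group would read at this place also stays open.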